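A few compounds are considered here, and "the series" means these few. Any claim that something is new, unique, unknown or untested is made for them only; others in the source may bear on it.

Measured so far:
- compound 1, `CCCCCCCCC(=O)NCc1cc(I)c(O)c(OC)c1`: 126 nM
- compound 2, `CCCCCCCCC(=O)NCc1cc(OC)c(O)cc1Br`: 16.1 nM

In an assay on HEK293 cells for inhibition of transient receptor potential cation channel subfamily V member 1 (Homo sapiens) (a lower number here means a stronger inhibitor, a higher number a weaker inhibitor), compound 1 gives the highest of the two numbers. Compound 2 gives the lower value, and the gap between the two lies beyond the scatter; the two structures differ in more than one place, so no single step can be read from them.

Compound 3, `C#Cc1cc(CNC(=O)CCCCCCCC)cc(OC)c1O`, is the next compound to be measured. It differs from compound 1 in one place: ethynyl in place of iodo on an aromatic carbon. Among the compounds with values here, the two measured compounds give no step of this kind, so the direction of the change is not set by the data. With nothing pointing either way, the step expected is a 1.3-fold higher number from compound 1 to compound 3 (0.10 log units; within the scatter), a change that would not stand out beyond the scatter. Compound 3 is therefore expected near 160 nM, with a range from 50 nM to 500 nM.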

Compound 3, half-maximal inhibitory concentration: 2740 nM
Beside the measured number, compound 3's estimate is 17-fold (1.23 log units) below it; the measured number lies above the stated range.
By their numbers in this assay, from the lowest: compound 2; then compound 1; then compound 3.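

In this assay, the aromatic carbon ortho to a hydroxy group and meta to a methoxy group is sensitive to its substituent: ethynyl in place of iodo gives a 22-fold higher number from compound 1 to compound 3 (1.34 log units; beyond the scatter). Within the data shown here, this is the first single-place step, and it shows that this one position can move the number well beyond the scatter, with the iodo compound the stronger of the pair. Nothing measured here bears on what lies behind this step.

Still open, from the compounds shown here alone, is how chloro, methyl or a nitrile at this position would compare with iodo and ethynyl, and so whether compound 1 or compound 3 is the more typical case. Also open, going by these compounds, is whether the same exchange on the core of compound 2 would give a step of similar size.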